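A few compounds are considered here, and "the series" means these few. Any claim that something is new, unique, unknown or untested is made for them only; others in the source may bear on it.

Among the compounds with values here, in an assay on CHO cells for displacement of a labelled ligand from prostaglandin D2 receptor 2 (Homo sapiens), read by scintillation counting (on this read-out lower numbers stand for stronger inhibition and higher numbers for weaker inhibition), compound 1 `Cc1ccc(S(=O)(=O)N(C)CC(C)C)cc1C#Cc1cc(Cl)ccc1OCC(=O)O` gives 4.2 nM, the lower of the two numbers measured so far. Compound 2 `CC(C)c1ccc(S(C)(=O)=O)cc1C#Cc1cc(C#N)ccc1OCC(=O)O` gives 12 nM in this assay, and the gap between the two lies beyond the usual scatter. Compound 3 `Cc1ccc(S(=O)(=O)N2CCOCC2)cc1C#Cc1cc(Cl)ccc1OCC(=O)O` has not yet been measured. It differs from compound 1 in a single place: morpholin-4-yl in place of isobutyl(methyl)amino on a sulfonyl sulfur. Within the data shown here, no measured pair shows this change, so its effect is not known from these data. In this assay a modest step toward a weaker number, a 1.9-fold higher number from compound 1 to compound 3 (0.28 log units; within the scatter), is expected. Compound 3 is therefore estimated at 8 nM, with a likely range from 3 nM to 25 nM.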

Compound 3, inhibition constant: 3.6 nM
The estimate for compound 3 lay 2.2-fold (0.35 log units) above the measured number; low and high end bracket the measured number.
By their numbers in this assay, from the lowest: compounds 3 and 1 (each within the scatter of the next); then compound 2.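

In this assay, the sulfonyl sulfur carries either isobutyl(methyl)amino or morpholin-4-yl without a reading beyond the scatter: the step is a 1.2-fold lower number from compound 1 to compound 3 (0.07 log units; within the scatter), so in this pair the open chain and the ring read alike. The hydrogen-bond acceptor that morpholin-4-yl brings shows no effect beyond the scatter here. No evidence on hand speaks to how this result arises. Open, going by these compounds, is whether a piperidine or piperazine ring, or a smaller dimethylamino group, on the sulfonyl sulfur would read alike as well.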